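The source may hold more compounds than are shown below. What is called first, only, known or untested is meant among the compounds shown, and "the series" means these compounds.

Three amides sharing one core have been measured in a functional assay on MCF7 cells (Homo sapiens) for antiproliferative activity, read by MTT assay, with a stated time of 72 h; on this read-out higher numbers stand for weaker inhibition and lower numbers for stronger inhibition. Compound 1 `CCc1ccccc1C(=O)Nc1ccc2nc(N3CCN(CC)CC3)cc(C)c2c1` gives 15800 nM. Compound 2 `CCN1CCN(c2cc(C)c3cc(NC(=O)c4ccc(Cl)cc4)ccc3n2)CC1` gives 1530 nM, and the change of 4-chlorophenyl in place of 2-ethylphenyl on a carbonyl carbon brings a 10-fold lower number from compound 1 to compound 2 (1.01 log units; beyond the scatter). Compound 3 `CCN1CCN(c2cc(C)c3cc(NC(=O)c4ccc5ccccc5n4)ccc3n2)CC1` gives 7060 nM in this assay, which places it second highest of the three: it lies nearest compound 1, with a 2.2-fold lower number from compound 1 to compound 3 (0.35 log units; beyond the scatter), and furthest from compound 2, with a 4.6-fold higher number from compound 2 to compound 3 (0.66 log units; beyond the scatter).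

Compound 4 `CCN1CCN(c2cc(C)c3cc(NC(=O)c4cccc(Br)c4)ccc3n2)CC1` differs from compound 3 in one place: 3-bromophenyl in place of quinolin-2-yl on a carbonyl carbon. For the measured compounds named here, the step that bears most directly on this is the one from compound 2 to compound 3, in which a halophenyl amide was exchanged for the quinolin-2-yl amide and the number rose by a 4.6-fold higher number from compound 2 to compound 3 (0.66 log units; beyond the scatter). Going by the values given here, compound 4 reverses that type of exchange, though with a different halogen and a different substituent position, for which no measured analogue exists. In this assay compound 4 is therefore expected to show a modest step toward a lower number, a 2.8-fold lower number from compound 3 to compound 4 (0.45 log units; beyond the scatter), with an estimated value of 2500 nM in the range 900 nM to 7000 nM.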

Compound 4, half-maximal inhibitory concentration: 11600 nM
Compound 4: the middle estimate sits 4.6-fold (0.67 log units) below what was measured, and the stated range ends below it.
By their numbers in this assay, from the lowest: compound 2; then compounds 3, 4 and 1 (each within the scatter of the next, the first and the last beyond it).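

In this assay, carrying a halogen on the phenyl amide does not by itself give the low number of compound 2: the 3-bromophenyl amide is clearly separated from the 4-chlorophenyl amide (a 7.6-fold higher number from compound 2 to compound 4 (0.88 log units; beyond the scatter)). It is not separated from the other two amides (a 1.6-fold higher number from compound 3 to compound 4 (0.22 log units; within the scatter); a 1.4-fold lower number from compound 1 to compound 4 (0.13 log units; within the scatter)), so neither the exchange of quinolin-2-yl nor that of 2-ethylphenyl for 3-bromophenyl on the carbonyl carbon can be read as a real change. Nothing measured here explains why compound 2 stands apart from the other three.

Compound 2 and compound 4 differ in both the halogen and its place on the phenyl ring, so it remains open which of the two accounts for the gap. Also open, from the compounds shown here alone, is how this series would respond to an amine or a carboxylic acid on the phenyl ring in place of the halogen.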